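This account rests on a few compounds, and the source may have more. Where it says the series, first, only, none or still open, it means among the compounds named here.

Compound 1 `CC(C)=CCC/C(C)=C/CC/C(C)=C/CSc1ccccc1C(=O)NCCN` gives > 50000 nM (a limit)
Compound 2 `CC(C)=CCC/C(C)=C/CC/C(C)=C/CSc1ccccc1C(=O)NCCCN` gives 17200 nM

Among the measured compounds shown here, in a functional assay on EJ cells (Homo sapiens) for cytotoxicity, read by MTT assay, with a stated time of 48 h (a lower number here means a stronger inhibitor, a higher number a weaker inhibitor), compound 2 (17200 nM) holds the only actual number so far. Compound 1 sits at a limit of the assay (> 50000 nM), which is not a number. Compound 3 `CC(C)=CCC/C(C)=C/CC/C(C)=C/CSc1ccccc1C(=O)NCCOCCN` alters the same chain: 2-aminoethoxy in place of aminomethyl on a saturated chain carbon, two bonds along the chain from an amide-type nitrogen on a saturated chain carbon, two bonds along the chain from an amide-type nitrogen. For the measured compounds named here, one measured step bears on this, aminomethyl in place of amino at that same place. Given an at least 2.9-fold lower number from compound 1 to compound 2 (0.46 log units; beyond the scatter) as that single step, which starts from a limit, a small further move toward a lower number is expected in this assay, possibly not beyond the scatter. The expected change is a 1.3-fold lower number from compound 2 to compound 3 (0.12 log units; within the scatter) by estimate. For compound 3 the estimated value is 13000 nM, with an expected range from 5000 nM to 35000 nM in this assay.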

Compound 3, half-maximal inhibitory concentration: 6130 nM
Estimate against measurement, compound 3: 2.1-fold (0.33 log units) above, and the stated range covers the measured number.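

In this assay, among the compounds shown here, 2-aminoethoxy in place of aminomethyl on a saturated chain carbon, two bonds along the chain from an amide-type nitrogen, gives a 2.8-fold lower number from compound 2 to compound 3 (0.45 log units; beyond the scatter); this is the first step with an actual number at both ends. The number falls with each longer amine-bearing chain across the three compounds, none going against this, and the whole change amounts to an at least 8.1-fold lower number from compound 1 to compound 3 (0.91 log units; beyond the scatter). That whole change starts from a limit of compound 1, which is not a number: the limit of > 50000 nM in this assay, at which 1 of the 3 values shown sits.

Compound 3 lengthens the chain and adds an ether oxygen in one change, so the two remain unseparated; an all-carbon chain of the same length ending in an amine would separate them. Also open, going by these compounds, is whether a still longer chain, or a dimethylamino end in place of the primary amine, continues the fall.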